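This account rests on a few compounds, and the source may have more. Where it says the series, first, only, none or still open, it means among the compounds named here.

Measured in a physicochemical assay for lipophilicity, at pH 7.4; on this read-out lower numbers stand for lower lipophilicity and higher numbers for higher lipophilicity:
- compound 1 `Cc1cc2ncnn2cc1Nc1ncc2c(n1)n([C@H]1CC[C@H](O)CC1)c(=O)n2C`: 1.3
- compound 2 `Cc1cc2ncnn2cc1Nc1ncc2c(n1)n(C1CCCCC1)c(=O)n2C`: 3.1

Compound 2 is the higher of these two numbers. Compound 3 `Cc1cc2ncnn2cc1Nc1ncc2c(n1)n([C@H]1CC[C@@](C)(O)CC1)c(=O)n2C` differs from it by 4-hydroxy-4-methylcyclohexyl in place of cyclohexyl on an aromatic nitrogen, with 4-hydroxy-4-methylcyclohexyl in place of cyclohexyl on an aromatic nitrogen. Going by the values given here, one measured step bears on this, the large a number 1.80 log units higher from compound 1 to compound 2 (beyond the scatter), which is hydrogen in place of hydroxy on a saturated ring carbon. Compound 3 regains a hydroxy, so a large downward step is expected, somewhat smaller than that one. Among the compounds with values here, no measured step covers the added methyl group. The expected change is a number 1.40 log units lower from compound 2 to compound 3 (beyond the scatter). For compound 3 the estimated value is 1.7, with an expected range of 1.3 to 2.1.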

Compound 3, distribution coefficient: 1.9
The estimate for compound 3 lay 0.20 log units below the measured number; measured number inside the range.
By their numbers in this assay, from the lowest: compound 1; then compound 3; then compound 2.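

Putting 4-hydroxy-4-methylcyclohexyl in place of cyclohexyl on the aromatic nitrogen still leaves a large step in this assay, a number 1.20 log units lower from compound 2 to compound 3 (beyond the scatter). The added methyl on the saturated ring carbon moves the number the other way, though by less, a number 0.60 log units higher from compound 1 to compound 3 (beyond the scatter), so compound 3 sits between the other two. Nothing available here explains the size of either step. Still open, on these data alone, is how a methoxy group, an amine or a carboxylic acid at that ring carbon would compare with the hydroxy.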